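Swapping the aryl amide for a dimethylaminoethyl amide

A few compounds are considered here, and "the series" means these few. Any claim that something is new, unique, unknown or untested is made for them only; others in the source may bear on it.

Values in a functional assay on A549 cells (Homo sapiens) for inhibition, read by MTT assay, with a stated time of 72 h; a higher number here means a weaker inhibitor, a lower number a stronger inhibitor:
- compound 1 `Cc1ccccc1NC(=O)CCC(=O)OCCCCCCSc1ccc([N+](=O)[O-])c2nonc12`: 4200 nM
- compound 2 `COc1ccccc1NC(=O)CCC(=O)OCCCCCCSc1ccc([N+](=O)[O-])c2nonc12`: 1870 nM
- compound 3 `COc1ccc(NC(=O)CCC(=O)OCCCCCCSc2ccc([N+](=O)[O-])c3nonc23)cc1OC`: 3890 nM

Two measured steps place compound 3 among the others: a 1.1-fold lower number from compound 1 to compound 3 (0.03 log units; within the scatter), and a 2.1-fold higher number from compound 2 to compound 3 (0.32 log units; beyond the scatter). Compound 4 `CN(C)CCNC(=O)CCC(=O)OCCCCCCSc1ccc([N+](=O)[O-])c2nonc12`, not yet measured, carries 2-(dimethylamino)ethyl in place of 3,4-dimethoxyphenyl on an amide-type nitrogen. The remaining measured step is a 2.2-fold lower number from compound 1 to compound 2 (0.35 log units; beyond the scatter). All three steps are small and keep an aromatic ring on that nitrogen, whereas this change removes it. They therefore give no direction, and no step beyond the scatter is expected in this assay, though with wide uncertainty. The expected step is a 1.1-fold lower number from compound 3 to compound 4 (0.05 log units; within the scatter). For compound 4 the estimated value is 3500 nM, with an expected range of 900 nM to 14000 nM.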

Compound 4, half-maximal inhibitory concentration: 5550 nM
For compound 4 the middle estimate is 1.6-fold (0.20 log units) below the measured one, and the stated range covers the measured number.
By their numbers in this assay, from the lowest: compound 2; then compounds 3, 1 and 4 (each within the scatter of the next).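

In this assay, an aromatic ring on the amide-type nitrogen proves dispensable: the ringless 2-(dimethylamino)ethyl group stays within the scatter of both 3,4-dimethoxyphenyl (a 1.4-fold higher number from compound 3 to compound 4 (0.15 log units; within the scatter)) and 2-methylphenyl (a 1.3-fold higher number from compound 1 to compound 4 (0.12 log units; within the scatter)). Only 2-methoxyphenyl goes against this, with a modest step beyond the scatter (a 3.0-fold higher number from compound 2 to compound 4 (0.47 log units; beyond the scatter)). The data available offer no explanation for this tolerance.

Going by these compounds, whether a morpholine ring, a longer chain before the dimethylamino group, or a carboxylic acid would also hold the number at this position remains open.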